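Replacing Acetyl With Pyridin-2-yl on a Ring Amine

The source may hold more compounds than are shown below. What is called first, only, known or untested is meant among the compounds shown, and "the series" means these compounds.

Going by the values given here, compound 1 `CC(=O)N1CCN(c2ccc([C@H]3CN(Cc4c(C)cccc4F)C[C@@H]3N(C)C)cc2)CC1` is one of two compounds measured so far in an ADME assay on microsomes from liver (Mus musculus) for metabolic stability, read by LC-MS, tested at 0.5 uM (a lower number here means slower removal, a higher number faster removal of the compound), where compound 1 gives 2830 mL/min/kg. That is the lowest of the two numbers, though its neighbour sits close: compound 2 `Cc1cccc(F)c1CN1C[C@H](c2ccc(-c3cnn(CC(N)=O)c3)cc2)[C@@H](N(C)C)C1`, which carries 1-(carbamoylmethyl)-1H-pyrazol-4-yl in place of 4-acetylpiperazin-1-yl on an aromatic carbon, gives 3750 mL/min/kg in this assay, a change of a 1.3-fold higher number from compound 1 to compound 2 (0.12 log units; within the scatter). Both numbers describe compounds that are removed quickly.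

Compound 3 `Cc1cccc(F)c1CN1C[C@H](c2ccc(N3CCN(c4ccccn4)CC3)cc2)[C@@H](N(C)C)C1` keeps the shared core and the six-membered non-aromatic ring with 2 nitrogen of compound 1, but changes what sits on the amine nitrogen in that ring: pyridin-2-yl in place of acetyl on an amine nitrogen in a ring. Among the compounds with values here, no measured step touches this position; the only step on record, from compound 1 to compound 2, alters a different place and stays within the scatter. Nothing here points to a move in either direction beyond the scatter, so compound 3 is expected to sit near compound 1, a step of a 1.1-fold higher number from compound 1 to compound 3 (0.03 log units; within the scatter). The estimate for compound 3 in this assay is 3000 mL/min/kg, ranging from 1400 mL/min/kg to 6500 mL/min/kg.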

Compound 3, clearance: 165000 mL/min/kg
Beside the measured number, compound 3's estimate is 55-fold (1.74 log units) below it; the whole stated range lies below it.
By their numbers in this assay, from the lowest: compounds 1 and 2 (each within the scatter of the next); then compound 3.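

The step from compound 1 to compound 2 changed a different place, and it stayed within the scatter. This new step shows that the amine nitrogen of the six-membered non-aromatic ring with 2 nitrogen is a place where a single change can shift the number in this assay a long way: a 58-fold higher number from compound 1 to compound 3 (1.77 log units; beyond the scatter). Acetyl and pyridin-2-yl have the same counts of hydrogen-bond donors and acceptors and neither carries a net charge, so those counts do not separate them; the counted differences are the rise from 3 to 6 heavy atoms and the arrival of a six-membered aromatic ring. Nothing available explains why the number moves so far.

With only these two groups shown at this place, it remains open whether the step goes with the aromatic ring, the nitrogen within that ring, or simply the larger group. Phenyl, pyrimidin-2-yl, cyclohexyl or a plain methyl on the same amine nitrogen, each compared with compound 1, would help to tell these possibilities apart.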